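The compounds below may be only part of what the source reports. "The series", "measured", "known", "first", "only" and "open" are said of these compounds alone.

Measured so far:
Compound 1 `COc1ccc(-n2c(SCC(=O)c3ccc4ccccc4c3)nnc2-c2cc(OC)c(OC)c(OC)c2)cc1`: 53400 nM
Compound 2 `COc1ccc(-n2c(SCC(=O)C3CC3)nnc2-c2cc(OC)c(OC)c(OC)c2)cc1`: > 60000 nM, a limit of the assay
Compound 3 `COc1cc(-c2nnc(SCC(=O)c3ccc4ccccc4c3)n2-c2ccc(N(C)C)cc2)cc(OC)c1OC`: > 60000 nM, a limit of the assay

In a functional assay on HT-29 cells (Homo sapiens) for inhibition, read by MTT assay, with a stated time of 48 h (on this read-out higher numbers stand for weaker inhibition and lower numbers for stronger inhibition), compound 1 gives 53400 nM. For compound 2 the value > 60000 nM is a limit of this assay, not a number. For compound 3 the value > 60000 nM is likewise a limit. The change cyclopropyl in place of naphthalen-2-yl on a carbonyl carbon gave an at least 1.1-fold higher number from compound 1 to compound 2 (0.05 log units; that floor lies within the scatter). The change dimethylamino in place of methoxy on an aromatic carbon gave an at least 1.1-fold higher number from compound 1 to compound 3 (0.05 log units; that floor lies within the scatter). Both steps end at the limit of > 60000 nM in this assay, at which 2 of the 3 values shown sit.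

Compound 4 `COc1cc(-c2nnc(SCC(=O)C3CC3)n2-c2ccc(N(C)C)cc2)cc(OC)c1OC` is not yet measured. It differs from compound 3 by cyclopropyl in place of naphthalen-2-yl on a carbonyl carbon, the same change as from compound 1 to compound 2, at the same place. Because compound 3 already sits at the limit of > 60000 nM in this assay, at which 2 of the 3 values shown sit, the expected step is a step that the limit leaves unreadable from compound 3 to compound 4, most likely again reported only as a limit. Compound 4 is estimated at 90000 nM in this assay, between 40000 nM and 250000 nM.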

Compound 4, half-maximal inhibitory concentration: > 60000 nM
Compound 4 ended at the assay's limit; the forecaster's own chance of this, stated with the estimate: 85%; the middle value does not contradict the limit.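

No step can be read from compound 3 to compound 4 or from compound 2 to compound 4, since all three compounds end at a limit, not a number: the limit of > 60000 nM in this assay, at which 3 of the 4 values shown sit.

From the compounds shown here alone, how strongly these three compounds inhibit in this assay stays open, and so does whether cyclopropyl in place of naphthalen-2-yl changes anything when dimethylamino stands in place of methoxy.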